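Halogen pattern on the pendant phenyl of compound 3

The source may report more compounds than this note shows. Statements on the series, on what has been measured and on what is new or still open speak of the compounds shown alone.

Measured in a functional assay on the whole organism for inhibition, with Mythimna separata as the target, with a stated time of 5 days; on this read-out higher numbers stand for an effect only at larger amounts of compound and lower numbers for an effect already at smaller amounts:
compound 1 `CC(C)(C)n1ncc(OCc2nnc(-c3ccc(Br)cc3)o2)c(Cl)c1=O`, 21400 nM
compound 2 `CC(C)(C)n1ncc(OCc2nnc(-c3cc(F)c(F)cc3F)o2)c(Cl)c1=O`, 75700 nM
compound 3 `CC(C)(C)n1ncc(OCc2nnc(-c3c(F)cccc3F)o2)c(Cl)c1=O`, 45400 nM

Compound 3 holds the second highest of the three numbers in this assay; its nearest neighbour is compound 2, with a 1.7-fold lower number from compound 2 to compound 3 (0.22 log units; within the scatter), and its furthest is compound 1, with a 2.1-fold higher number from compound 1 to compound 3 (0.33 log units; beyond the scatter). Compound 4 `CC(C)(C)n1ncc(OCc2nnc(-c3ccc(Cl)cc3F)o2)c(Cl)c1=O` differs from compound 3 by 4-chloro-2-fluorophenyl in place of 2,6-difluorophenyl on an aromatic carbon. Among the measured compounds shown here, the steps that bear on this are a 3.5-fold higher number from compound 1 to compound 2 (0.55 log units; beyond the scatter) and a 2.1-fold higher number from compound 1 to compound 3 (0.33 log units; beyond the scatter), both modest rises on leaving 4-bromophenyl. Compound 4 keeps one fluorine but, like compound 1 with its bromine, carries a second halogen in the 4-chloro-2-fluorophenyl group, so a modest fall toward the number of compound 1 is expected, a 1.5-fold lower number from compound 3 to compound 4 (0.18 log units; within the scatter). Compound 4 is therefore estimated at 30000 nM, with a range of 12000 nM to 75000 nM.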

Compound 4, half-maximal effective concentration: 10400 nM
Beside the measured number, compound 4's estimate is 2.9-fold (0.46 log units) above it; measured number below the stated range.
By their numbers in this assay, from the lowest: compound 4; then compound 1; then compounds 3 and 2 (each within the scatter of the next).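

In this assay, the 4-chloro-2-fluorophenyl group of compound 4 gives the lowest number of the four, below those of the two fluorine-only compounds (a 4.4-fold lower number from compound 3 to compound 4 (0.64 log units; beyond the scatter) and a 7.3-fold lower number from compound 2 to compound 4 (0.86 log units; beyond the scatter)) and also below that of the 4-bromophenyl compound (a 2.1-fold lower number from compound 1 to compound 4 (0.31 log units; beyond the scatter)). This position can therefore go below the number of compound 1, and among these four compounds the two with chlorine or bromine give lower numbers than the two carrying only fluorine. Nothing available explains this difference.

Open, going by these compounds, is whether a plain 4-chlorophenyl group would keep this number, and how a methoxy group, a nitrile or an amine would fare in place of the chlorine.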